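Octyl Replacing Hydroxyethyl on a Coumarin-Triazole Series

This account rests on a few compounds, and the source may have more. Where it says the series, first, only, none or still open, it means among the compounds named here.

Compound 1 `O=c1cc(Cn2cc(CCCCl)nn2)c2ccc(O)cc2o1` — 75800 nM
Compound 2 `CC(O)c1cn(Cc2cc(=O)oc3cc(O)ccc23)nn1` — > 100000 nM

In a functional assay on CFPAC-1 cells (Homo sapiens) for inhibition, read by MTT assay, with a stated time of 72 h (a lower number here means a stronger inhibitor, a higher number a weaker inhibitor), compound 1 gives 75800 nM. Compound 2 reaches only the assay limit, > 100000 nM. Compound 2 therefore stands at the weak end of the numbers shown, with no exact value. Compound 3 `CCCCCCCCc1cn(Cc2cc(=O)oc3cc(O)ccc23)nn1` differs from compound 2 by octyl in place of 1-hydroxyethyl on an aromatic carbon. For the measured compounds named here, the only measured step that bears on it is an at least 1.3-fold higher number from compound 1 to compound 2 (0.12 log units; that floor lies within the scatter), which swapped a chain lacking donors for the hydroxyethyl group, as in the limit of > 100000 nM in this assay, at which 1 of the 2 values shown sits. Reversing that direction, compound 3 is expected to give 50000 nM, between 15000 nM and 150000 nM, a step of an at least 2.0-fold lower number from compound 2 to compound 3 (0.30 log units; that floor lies within the scatter) that may not exceed the scatter.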

Compound 3, half-maximal inhibitory concentration: 62700 nM
Estimate against measurement, compound 3: 1.3-fold (0.10 log units) below, within the range that was stated.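

Octyl in place of 1-hydroxyethyl gives a measurable value where compound 2 gave only a limit: an at least 1.5-fold lower number from compound 2 to compound 3 (0.20 log units; that floor lies within the scatter). That floor rests on a limit and not on a number: the limit of > 100000 nM in this assay, at which 1 of the 3 values shown sits. Octyl and 3-chloropropyl at this position cannot be told apart: a 1.2-fold lower number from compound 1 to compound 3 (0.08 log units; within the scatter).

The compounds shown leave open how far compound 2 actually lies from the other two. They also leave open whether an amine or a carboxylic acid at the end of the chain would move the number beyond the scatter.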